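Sulfonyl substituent swaps and microsomal stability

The compounds below may be only part of what the source reports. "The series", "measured", "known", "first", "only" and "open" are said of these compounds alone.

Measured so far:
compound 1 `O=C(NS(=O)(=O)c1ccc(F)cc1)c1ccc(Nc2nc(NC3(c4ccc(Cl)cc4)CC3)nc(OCC(F)(F)F)n2)cc1`: 100%
compound 2 `CC(C)(C)OC(=O)NCCS(=O)(=O)NC(=O)c1ccc(Nc2nc(NC3(c4ccc(Cl)cc4)CC3)nc(OCC(F)(F)F)n2)cc1`: 92%
compound 3 `O=C(NS(=O)(=O)CCNCc1ccccc1)c1ccc(Nc2nc(NC3(c4ccc(Cl)cc4)CC3)nc(OCC(F)(F)F)n2)cc1`: 99%

In an ADME assay on microsomes from liver (Homo sapiens) for metabolic stability, with a stated time of 10 min (on this read-out lower numbers stand for a less stable compound and higher numbers for a more stable compound), compound 1 gives 100%, the highest of the three numbers, though neither neighbour is separated from it beyond the scatter: a number 1 percentage points lower from compound 1 to compound 3 (within the scatter) and a number 8 percentage points lower from compound 1 to compound 2 (within the scatter). Between the two chain-bearing analogues the step is likewise small, a number 7 percentage points higher from compound 2 to compound 3 (within the scatter).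

Compound 4 `NCCS(=O)(=O)NC(=O)c1ccc(Nc2nc(NC3(c4ccc(Cl)cc4)CC3)nc(OCC(F)(F)F)n2)cc1` is not yet measured in this assay. It differs from compound 1 in one place: 2-aminoethyl in place of 4-fluorophenyl on a sulfonyl sulfur

Among the compounds with values here, two measured steps bear on this change, since both also exchange the 4-fluorophenyl on the sulfonyl sulfur for a two-carbon chain carrying a nitrogen: a number 8 percentage points lower from compound 1 to compound 2 (within the scatter) and a number 1 percentage points lower from compound 1 to compound 3 (within the scatter). Both stay within the scatter, and the variation of the group on that nitrogen, a number 7 percentage points higher from compound 2 to compound 3 (within the scatter), is also within the scatter. The expected step in this assay is therefore none beyond the scatter, a number 5 percentage points lower from compound 1 to compound 4 (within the scatter). Compound 4 is accordingly estimated at 95%, in the range 85% to 100%.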

Compound 4, percent of the compound remaining: 100%
Estimate against measurement, compound 4: 5 percentage points below, within the range that was stated.
By their numbers in this assay, from the lowest: compounds 2, 3, 1 and 4 (each within the scatter of the next).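

In this assay, the bare 2-aminoethyl on the sulfonyl sulfur cannot be told apart from 4-fluorophenyl, with no change at the digits printed from compound 1 to compound 4 (within the scatter), so this position accepts a short chain with an unsubstituted amine as well as the aromatic ring. Taking the substituent off the amine nitrogen also stays within the scatter, whether benzyl leaves, with a number 1 percentage points higher from compound 3 to compound 4 (within the scatter), or tert-butoxycarbonyl leaves, with a number 8 percentage points higher from compound 2 to compound 4 (within the scatter), so among compounds 2, 3 and 4 the read-out does not separate the three nitrogen states. Nothing available explains why these values coincide.

All four compounds sit within the scatter of one another, so no group at this position has yet moved the read-out. Going by these compounds, whether a longer chain, a carboxylic acid at the chain end or a tertiary amine would do so remains open.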